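This account rests on a few compounds, and the source may have more. Where it says the series, first, only, none or still open, it means among the compounds named here.

Working notes on the series, read in an ADME assay on HeLa cells (Homo sapiens) for cytotoxicity, read by MTT assay; on this read-out higher numbers stand for weaker inhibition and lower numbers for stronger inhibition. Compound 1 (`COc1ccc(C[C@H]2COC(=O)[C@@H]2Cc2ccc(OCc3cn(Cc4ccc(F)cc4)nn3)c(OC)c2)cc1OC`) gives a measured 198000 nM. Compound 2 (`COc1ccc(C[C@H]2COC(=O)[C@@H]2Cc2ccc(OCC(=O)N3CCOCC3)c(OC)c2)cc1OC`) gives >= 600000 nM. From the compounds shown here alone, that value is a limit of the assay and not a number, so the exact position of compound 2 is unknown.

Compound 3 (`COc1ccc(C[C@H]2COC(=O)[C@@H]2Cc2ccc(OCc3cn(-c4ccccc4)nn3)c(OC)c2)cc1OC`) has not yet been measured. It carries 1-phenyl-1H-1,2,3-triazol-4-yl in place of (morpholin-4-yl)carbonyl on a saturated chain carbon bound to an oxygen on an aromatic ring.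

For the measured compounds named here, no step between measured compounds is available to guide the size of this change. Going by the values given here, the closest reference is compound 1 at 198000 nM, the only measured compound with a five-membered aromatic ring with 3 hetero atoms on that chain, and the expectation rests on this single value. The expected step, an at least 2.7-fold lower number from compound 2 to compound 3 (0.43 log units; beyond the scatter), runs toward lower numbers, that is, stronger inhibition, and its size is uncertain since it starts from a limit. Compound 3 is estimated at 220000 nM, with an expected range of 90000 nM to 500000 nM.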

Compound 3, half-maximal inhibitory concentration: 124000 nM
For compound 3 the middle estimate is 1.8-fold (0.25 log units) above the measured one, within the range that was stated.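

In this assay, 1-phenyl-1H-1,2,3-triazol-4-yl in place of (morpholin-4-yl)carbonyl on a saturated chain carbon bound to an oxygen on an aromatic ring gives an at least 4.8-fold lower number from compound 2 to compound 3 (0.68 log units; beyond the scatter), which puts a first, one-sided size on this change at this position. Compound 2 stands at a limit and not at a number, so the true size of that step stays unknown: the limit of >= 600000 nM in this assay, at which 1 of the 3 values shown sits.

Within the triazole-bearing pair, phenyl in place of 4-fluorobenzyl on an aromatic nitrogen gives a 1.6-fold lower number from compound 1 to compound 3 (0.20 log units; within the scatter), so these two groups on that nitrogen are not told apart in this assay.

The compounds shown leave open whether a much smaller group on that aromatic nitrogen, such as methyl, or a basic amine or a carboxylic acid on the phenyl ring, would shift the value beyond the scatter. They also leave open whether the step from compound 2 belongs to the five-membered aromatic ring with 3 hetero atoms itself or to the aromatic or benzyl group it carries, since a 1H-1,2,3-triazol-4-yl group with only a hydrogen on that nitrogen does not stand among them.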